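Carboxy for dimethylamino on the amide chain

A few compounds are considered here, and "the series" means these few. Any claim that something is new, unique, unknown or untested is made for them only; others in the source may bear on it.

Values in a functional assay on MCF7 cells (Homo sapiens) for antiproliferative activity, read by MTT assay, with a stated time of 72 h; on this read-out lower numbers stand for stronger inhibition and higher numbers for weaker inhibition:
compound 1 `CCn1c(C(=O)NCc2ccc(OC)cc2)ccc1C(CC)(CC)c1ccc(C#CC(O)(CC)CC)c(C)c1` gives > 50000 nM (a limit)
compound 2 `CCCCC(=O)c1ccc(C(CC)(CC)c2ccc(C#CC(O)(CC)CC)c(C)c2)n1CC` gives > 50000 nM (a limit)
compound 3 `CCn1cc(C(CC)(CC)c2ccc(C#CC(O)(CC)CC)c(C)c2)cc1C(=O)NCCN(C)C` gives 13400 nM

Among the measured compounds shown here, compound 3 provides the only true number. The other results stand at the limit of > 50000 nM in this assay, at which 2 of the 3 values shown sit.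

Compound 4 `CCn1cc(C(CC)(CC)c2ccc(C#CC(O)(CC)CC)c(C)c2)cc1C(=O)NCCC(=O)O` carries carboxy in place of dimethylamino on a saturated chain carbon, two bonds along the chain from an amide-type nitrogen.

For the measured compounds named here, the only measured step is a step that the two limits leave unreadable from compound 1 to compound 2. It is a different change and gives no size to carry over. Going by the values given here, the expectation therefore rests on thin ground: compound 3, at 13400 nM, is the only compound with dimethylamino and the only one with a number, though compounds 1 and 2 also differ from it elsewhere. Weaker inhibition is expected, as a 2.6-fold higher number from compound 3 to compound 4 (0.42 log units; beyond the scatter), and a result at the limit would be no surprise. For compound 4 the estimate is 35000 nM, with an expected range of 13000 nM to 50000 nM.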

Compound 4, half-maximal inhibitory concentration: 30600 nM
Compound 4: middle estimate off by 1.1-fold (0.06 log units), on the high side; low and high end bracket the measured number.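

Dimethylamino is not required for a readable value at this place, on a saturated chain carbon, two bonds along the chain from an amide-type nitrogen: in this assay the change to carboxy gives a 2.3-fold higher number from compound 3 to compound 4 (0.36 log units; beyond the scatter). Swapping one end group for the other thus shifts the value only modestly, and this is the first step in the series with a readable size. Compound 1 and compound 2 remain limits and not numbers, so their step cannot be read: the limit of > 50000 nM in this assay, at which 2 of the 4 values shown sit.

Still open, on these data alone, is whether a primary amine, a hydroxyl or a methyl ester at the same place would fall with compound 3, with compound 4 or elsewhere. A longer chain carrying either end group is also untested by the compounds shown, so the role of chain length remains unknown.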